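The source may hold more compounds than are shown below. What is called first, only, known or untested is meant among the compounds shown, and "the series" means these compounds.

Compound 1 `Cc1cnc(NC(=O)COc2ccc(/C=C3\SC(=O)NC3=O)cc2)s1` — in a functional assay on K562 cells (Homo sapiens) for cytotoxicity, read by sulforhodamine B assay, with a stated time of 48 h (a lower number here means a stronger inhibitor of growth, a higher number a weaker inhibitor of growth), compound 1 gives only a limit, < 100000 nM.
Compound 2 `O=C(COc1ccc(/C=C2\SC(=O)NC2=O)cc1)Nc1nc2ccccc2s1` — in this assay compound 2 likewise gives only a limit, < 100000 nM.
Compound 3 `O=C(COc1ccc(/C=C2\SC(=O)NC2=O)cc1)Nc1ncc([N+](=O)[O-])s1` — in this assay compound 3 also gives only a limit, < 100000 nM.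

Compound 3 therefore stands nowhere in particular among the three: all that is known is the limit of < 100000 nM in this assay, at which 3 of the 3 values shown sit. The steps between the measured compounds carry no size, since a step that the two limits leave unreadable from compound 1 to compound 2, a step that the two limits leave unreadable from compound 1 to compound 3 and a step that the two limits leave unreadable from compound 2 to compound 3 are each hidden by the limits. Compound 4 `O=C(COc1ccc(/C=C2\SC(=O)NC2=O)cc1)Nc1ccccn1` differs from compound 3 by pyridin-2-yl in place of 5-nitro-1,3-thiazol-2-yl on an amide-type nitrogen. For the measured compounds named here, no measured step bears on this change with a readable size. Compound 4 is expected to fall at 30000 nM in this assay, within 5000 nM to 100000 nM. The expected step is a step that the limit leaves unreadable from compound 3 to compound 4, an estimate only.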

Compound 4, concentration for total growth inhibition: < 100000 nM
Compound 4: no number, only a limit; the forecaster's own chance of this, stated with the estimate: 50%; the middle value lies beyond the limit too.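

In this assay compound 4 gives only a limit, < 100000 nM. For the compounds shown here, no step among compound 1, compound 2, compound 3 and compound 4 can be read: the limit of < 100000 nM in this assay, at which 4 of the 4 values shown sit. The compounds shown leave open whether the group on the amide-type nitrogen changes growth inhibition at all.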